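Chloro in place of hydrogen: from compound 3 to compound 4

A few compounds are considered here, and "the series" means these few. Any claim that something is new, unique, unknown or untested is made for them only; others in the source may bear on it.

Measured so far:
Compound 1 `CCN1CCCC1CNC(=O)c1cc(N(C)S(C)(=O)=O)c(Cl)cc1OC` gives 7.7 mg/kg in a functional assay on the whole organism for inhibition, with Mus musculus as the target; a higher number here means that more compound is needed for the effect, a lower number that less compound is needed.
Compound 2 `CCN1CCCC1CNC(=O)c1cc(N(C)S(=O)(=O)N(C)C)c(Cl)cc1OC` gives 31.8 mg/kg in this assay.
Compound 3 `CCN1CCCC1CNC(=O)c1cc(NS(C)(=O)=O)ccc1OC` reaches only the limit > 50 mg/kg in this assay and has no number.

Among the measured compounds shown here, the one measured step, a 4.1-fold higher number from compound 1 to compound 2 (0.62 log units; beyond the scatter), concerns the group on the sulfonyl sulfur and does not touch the change considered here. Compound 3 stands at the limit of > 50 mg/kg in this assay, at which 1 of the 3 values shown sits, the only one of the three at that limit. Compound 4 `CCN1CCCC1CNC(=O)c1cc(NS(C)(=O)=O)c(Cl)cc1OC` differs from compound 3 by chloro in place of hydrogen on an aromatic carbon. No measured step covers this change, so its size cannot be read off from the shown steps. The only point of reference is that compound 1 carries the same chloro and gives a measured number in this assay rather than a limit. On that basis compound 4 is expected to fall within the measurable range, with an estimate of 12 mg/kg (from 4 mg/kg to 40 mg/kg). The expected step is therefore an at least 4.1-fold lower number from compound 3 to compound 4 (0.61 log units; beyond the scatter), downward from the limit.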

Compound 4, dose for half-maximal effect: 9.1 mg/kg
For compound 4 the middle estimate is 1.3-fold (0.12 log units) above the measured one; the range from low to high includes it.
By their numbers in this assay, from the lowest: compounds 1 and 4 (each within the scatter of the next); then compound 2. At a limit, above all of these: compound 3.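

Compound 3 stands only at a limit of this assay, not at a number: the limit of > 50 mg/kg in this assay, at which 1 of the 4 values shown sits. Chloro on this aromatic carbon, ortho to the methanesulfonamido group, gives the first measured value for a compound with hydrogen on the sulfonamide nitrogen, and the step has only a lower bound (an at least 5.4-fold lower number from compound 3 to compound 4 (0.73 log units; beyond the scatter)). With chloro in place, hydrogen and methyl on the sulfonamide nitrogen are not separated (a 1.2-fold higher number from compound 1 to compound 4 (0.07 log units; within the scatter)), whereas methanesulfonamido does separate from (dimethylsulfamoyl)(methyl)amino (a 3.5-fold lower number from compound 2 to compound 4 (0.54 log units; beyond the scatter)).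

Chloro is the only group shown at this position, so it remains open whether fluoro, bromo, methyl or a carboxylic acid there would keep the number in the measured range. Also open, going by these compounds, is whether a longer chain than methyl on the sulfonyl sulfur would keep it there.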